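A few compounds are considered here, and "the series" means these few. Any claim that something is new, unique, unknown or untested is made for them only; others in the source may bear on it.

Compounds measured so far:
compound 1, `N=C(N)c1ccc(-c2ccc(-c3cc(Cl)cc(Cl)c3)s2)cc1`, 225 nM
compound 2, `COc1cc(OC)cc(-c2ccc(-c3ccc(C(=N)N)c(F)c3)s2)c1`, 262 nM

The study concerns growth inhibition measured in a functional assay on K562 cells (Homo sapiens) for inhibition, read by sulforhodamine B assay, with a stated time of 48 h; on this read-out higher numbers stand for weaker inhibition of growth and lower numbers for stronger inhibition of growth. Compound 1, `N=C(N)c1ccc(-c2ccc(-c3cc(Cl)cc(Cl)c3)s2)cc1`, gives 225 nM in this assay. Compound 2, `COc1cc(OC)cc(-c2ccc(-c3ccc(C(=N)N)c(F)c3)s2)c1`, gives 262 nM in this assay. The two values sit close together, and the gap between them falls within the usual scatter of repeated measurements, so the numbers show no separation between compound 2 and compound 1.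

The next compound, compound 3, `COc1cc(OC)cc(-c2ccc(-c3ccc(C(=N)N)cc3)s2)c1`, has not yet been measured. It differs from compound 2 in one place: hydrogen in place of fluoro on an aromatic carbon. Within the data shown here, no step between measured compounds tells how such a change plays out here; the two values so far belong to compounds that differ in several places at once, so they give no guide of their own.

Without such a guide, compound 3 is expected to stay close to compound 2, with a step of a 1.0-fold lower number from compound 2 to compound 3 (0.02 log units; within the scatter) that is not expected to go beyond the scatter in either direction. The estimate for compound 3 in this assay is 250 nM, with a range from 120 nM to 550 nM.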

Compound 3, concentration for 50% growth inhibition: 418 nM
Estimate against measurement, compound 3: 1.7-fold (0.22 log units) below; low and high end bracket the measured number.
By their numbers in this assay, from the lowest: compounds 1, 2 and 3 (each within the scatter of the next).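

In this assay, among these compounds, hydrogen in place of fluoro on this aromatic carbon, ortho to a group of 3 heavy atoms and meta to a large group, gives a 1.6-fold higher number from compound 2 to compound 3 (0.20 log units; within the scatter), and this is the first step that isolates a single change. Compound 2 and compound 3 cannot be told apart on this read-out, so the fluoro is not shown to matter for growth inhibition at this place, and this position accepts either fluoro or hydrogen without a change that stands clear of the scatter. Nothing measured on these compounds offers an explanation for this small step or tests what lies behind it.

On these data alone, it remains open whether another group on the same aromatic carbon, such as a chlorine, a methoxy group, an amine or a carboxylic acid, would shift the number beyond the scatter. As far as these compounds go, it is also open whether hydrogen in place of fluoro would give a similar step in a compound carrying the two chloro groups of compound 1 instead of the two methoxy groups of compound 2 and compound 3.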